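A Cyano Group Replaces the Ether Chain of Compound 3

A few compounds are considered here, and "the series" means these few. Any claim that something is new, unique, unknown or untested is made for them only; others in the source may bear on it.

In an ADME assay on a cell-free system (plasma) for protein binding, using equilibrium dialysis, compound 3 `CC#C[C@@H](CC(=O)O)c1ccc(OCc2ccc3nc(-c4ccc(OCCOC)cc4)nn3c2)cc1` gives > 99%, which is a limit and not a number. Compound 1 `CC#C[C@@H](CC(=O)O)c1ccc(OCc2ccc3nc(-c4ccc(OC(F)F)cc4)nn3c2)cc1` gives > 99%, also a limit. Compound 2 `CC#C[C@@H](CC(=O)O)c1ccc(OCc2ccc3nc(-c4ccc(C(C)C)cc4)nn3c2)cc1` gives > 99%, again a limit. Compound 4 `CC#C[C@@H](CC(=O)O)c1ccc(OCc2ccc3nc(-c4ccc(C#N)cc4)nn3c2)cc1` carries cyano in place of 2-methoxyethoxy on an aromatic carbon. Three measured steps change this same group: a step that the two limits leave unreadable from compound 1 to compound 2, a step that the two limits leave unreadable from compound 1 to compound 3 and a step that the two limits leave unreadable from compound 2 to compound 3. None of them has a size that can be read, because of the limit of > 99% in this assay, at which 3 of the 3 values shown sit. The expected change, an at least 1.1-fold higher unbound fraction from compound 3 to compound 4 (0.04 log units; that floor lies within the scatter), is therefore none beyond the scatter, judged from compound 3 and its two neighbours. Compound 4 is expected at 98.9%, with an estimated range from 97.2% to 99.6%.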

Compound 4, plasma protein binding: > 99%
Compound 4: a limit, no number (the forecaster's own chance of this, stated with the estimate: 50%); middle value at least 1.1-fold (0.04 log units) (unbound fraction) from the limit.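

The steps from compound 1, compound 2 and compound 3 to compound 4 cannot be read in size, because all four compounds sit at one limit: the limit of > 99% in this assay, at which 4 of the 4 values shown sit. The compounds shown leave open how far plasma protein binding actually differs among these four.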